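Trimming a Chloro Group: Expected Stability of Compound 4

The source may report more compounds than this note shows. Statements on the series, on what has been measured and on what is new or still open speak of the compounds shown alone.

Compound 3 `Cc1nc(-c2ccccc2)c(C(=O)N2CCN(c3cc(Cl)cc(Cl)c3)CC2)o1` stands second highest of the three measured in an ADME assay (liver) for metabolic stability, with Liver microsome (Homo sapiens) as the target, read by LC-MS, using microsomes, with a stated time of 1 h, tested at 5 uM (on this read-out higher numbers stand for a more stable compound and lower numbers for a less stable compound), where compound 3 gives 66.3%. Compound 1 `Cc1nc(-c2ccccc2F)c(C(=O)N2CCN(c3cc(Cl)cc(Cl)c3)CC2)o1` gives 82.3% in this assay, and compound 2 `Cc1nc(-c2ccccc2)c(C(=O)N2CCN(c3cccc(C#N)c3)CC2)o1` gives 8%. Compound 4 `Cc1nc(-c2ccccc2)c(C(=O)N2CCN(c3cccc(Cl)c3)CC2)o1` has not yet been measured; it differs from compound 3 in one place: hydrogen in place of chloro on an aromatic carbon. Two measured steps frame this change. The step of a number 58.3 percentage points higher from compound 2 to compound 3 (beyond the scatter) shows a large gain on moving from a 3-cyanophenyl to a 3,5-dichlorophenyl group, while the step of a number 16 percentage points lower from compound 1 to compound 3 (beyond the scatter) was modest. Removing one chloro group from compound 3 is therefore expected to lower the read-out by a moderate step, a number 26.3 percentage points lower from compound 3 to compound 4 (beyond the scatter). Compound 4 is expected to give about 40%, within a range from 15% to 65%.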

Compound 4, percent of the compound remaining: 13.5%
Compound 4: the middle estimate sits 26.5 percentage points above what was measured; measured number outside the range, below it.
By their numbers in this assay, from the lowest: compounds 2 and 4 (each within the scatter of the next); then compound 3; then compound 1.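

In this assay, this position on the ring proves decisive: hydrogen in place of chloro gives a number 52.8 percentage points lower from compound 3 to compound 4 (beyond the scatter). A single chloro group does not match the pair, since chloro in place of cyano gives only a number 5.5 percentage points higher from compound 2 to compound 4 (within the scatter), so the large gain of compound 3 over compound 2 appears only with the 3,5-dichlorophenyl group. No available evidence accounts for this dependence on the second chloro group. The compounds shown leave open whether a fluoro or methyl group on this aromatic carbon would preserve the stability of compound 3.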